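Swapping an Amino Group for Methyl on Two Cores

The source may hold more compounds than are shown below. What is called first, only, known or untested is meant among the compounds shown, and "the series" means these compounds.

Three compounds have been measured in a functional assay on V79 cells (Cricetulus griseus) for cytotoxicity, read by colony formation; on this read-out lower numbers stand for stronger inhibition and higher numbers for weaker inhibition:

compound 1, `Nc1c(F)c(N2CCC(N)C2)c(F)c2c1c(=O)c(C(=O)O)cn2C1CC1`, 15 ug/mL
compound 2, `Cc1c(F)c(N2CCC(N)C2)c(F)c2c1c(=O)c(C(=O)O)cn2C1CC1`, 11 ug/mL
compound 3, `CCNCC1CCN(c2cc3c(c(N)c2F)c(=O)c(C(=O)O)cn3C2CC2)C1`, 61 ug/mL

The change from compound 1 to compound 2 is methyl in place of amino on an aromatic carbon, and it gave a 1.4-fold lower number from compound 1 to compound 2 (0.13 log units; within the scatter). Compound 3 carries a different core; how its core differs from the core of compound 1 is not broken down here, but its number is higher than the numbers of both compound 1 and compound 2.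

Compound 4, `CCNCC1CCN(c2cc3c(c(C)c2F)c(=O)c(C(=O)O)cn3C2CC2)C1`, has not yet been measured. It differs from compound 3 by methyl in place of amino on an aromatic carbon. Within the data shown here, this is the same kind of change as the one from compound 1 to compound 2, not the same change: here the place is meta to a 3-((ethylamino)methyl)pyrrolidin-1-yl group, whereas in compound 1 it is meta to a 3-aminopyrrolidin-1-yl group and para to a fluoro group. Because the earlier change gave a 1.4-fold lower number from compound 1 to compound 2 (0.13 log units; within the scatter), the step from compound 3 to compound 4 is expected to be of similar size, a 1.4-fold lower number from compound 3 to compound 4 (0.13 log units; within the scatter). Compound 4 is therefore estimated at 45 ug/mL in this assay, most likely between 25 ug/mL and 85 ug/mL.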

Compound 4, half-maximal inhibitory concentration: 42 ug/mL
The estimate for compound 4 lay 1.1-fold (0.03 log units) above the measured number; the measured number falls inside the stated range.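

Swapping amino for methyl on the second core gave a 1.5-fold lower number from compound 3 to compound 4 (0.16 log units; within the scatter) in this assay. Set beside the same swap on the first core, the two steps agree: the same change on two cores in this assay, a 1.4-fold lower number (0.13 log units; within the scatter) from compound 1 to compound 2 and a 1.5-fold lower number (0.16 log units; within the scatter) from compound 3 to compound 4, 1.1-fold (0.03 log units) apart, within the scatter of two such steps. This shows that in this assay the swap stayed small on both cores, but since each step lies within the scatter, what carries over is only the lack of a clear change, and two cores cannot establish a rule for the whole series or predict a swap that does shift the number.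

The compounds shown leave open whether another group on the same aromatic carbon, such as an ethyl group, a methoxy group or a dimethylamino group, would move the number beyond the scatter. They also leave open whether the swap would stay this small with a group other than the 3-aminopyrrolidin-1-yl or 3-((ethylamino)methyl)pyrrolidin-1-yl group on the core, such as a longer amine chain.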